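The compounds below may be only part of what the source reports. "The series", "measured", "known", "first", "only" and "open" are said of these compounds alone.

Measured compounds:

Compound 1, `CNC(=O)c1cc(Oc2ccc3nc(Nc4ccccc4Br)ncc3c2)ccn1`, in an ADME assay on Caco-2 cells (Homo sapiens) for permeability, in the apical to basolateral direction (a higher number here means that the compound crosses the layer faster, a lower number that the compound crosses the layer more slowly), gives < 1 10^-6 cm/s, which is a limit of the assay rather than a number.

Compound 2, `CNC(=O)c1cc(Oc2ccc3nc(Nc4cccc(OC(F)(F)F)c4)ncc3c2)ccn1`, in this assay gives < 1 10^-6 cm/s, again a limit.

Compound 3, `CNC(=O)c1cc(Oc2ccc3nc(Nc4cccc(C(C)C)c4)ncc3c2)ccn1`, in this assay gives < 1 10^-6 cm/s, also a limit.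

Compound 3 therefore stands at the floor of what this assay can report, and so do its two companions (the limit of < 1 10^-6 cm/s in this assay, at which 3 of the 3 values shown sit). Within the data shown here, none of the measured steps can be read: a step that the two limits leave unreadable from compound 1 to compound 2, a step that the two limits leave unreadable from compound 1 to compound 3 and a step that the two limits leave unreadable from compound 2 to compound 3 all run between limits, so their size is unknown.

Compound 4, `CNC(=O)c1cc(Oc2ccc3nc(Nc4ccc(OC)cc4)ncc3c2)ccn1`, differs from compound 3 in one place: 4-methoxyphenyl in place of 3-isopropylphenyl on a nitrogen on an aromatic ring. Among the measured compounds shown here, the measured steps give no readable guidance on the size of this change, only that three different groups on that nitrogen all left the compounds at the limit. The expectation for the step from compound 3 to compound 4 in this assay is therefore a step that the limit leaves unreadable from compound 3 to compound 4, with no shift beyond the scatter foreseen. Compound 4 is estimated at 0.7 10^-6 cm/s, ranging from 0.2 10^-6 cm/s to 2.5 10^-6 cm/s, and most likely again reported only as a limit.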

Compound 4, apparent permeability: < 1 10^-6 cm/s
Compound 4: a limit, no number (the forecaster's own chance of this, stated with the estimate: 65%); the middle value lies beyond the limit too.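

Compound 4 also returns a limit rather than a number, so its steps from compound 1, compound 2 and compound 3 cannot be read: the limit of < 1 10^-6 cm/s in this assay, at which 4 of the 4 values shown sit.

The compounds shown leave open how far apart their true values lie in this assay, and whether any group on that nitrogen would give a readable number.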